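This account rests on a few compounds, and the source may have more. Where it says the series, first, only, none or still open, it means among the compounds named here.

Measured in a physicochemical assay for lipophilicity, using the shake flask method, in phosphate buffer, with a stated time of 1 h; on this read-out higher numbers stand for higher lipophilicity and lower numbers for lower lipophilicity:
- Compound 1 `CC(C)(C)C(=O)OC[C@H]1O[C@@H](n2cnc3c(N)ncnc32)[C@@H](O)[C@@H]1O`: 1.63
- Compound 2 `CC(C)(C)CC(=O)OC[C@H]1O[C@@H](n2cnc3c(N)ncnc32)[C@@H](O)[C@@H]1O`: 1.7
- Compound 3 `Nc1ncnc2c1ncn2[C@@H]1O[C@H](COC(=O)CCc2ccccc2)[C@@H](O)[C@@H]1O`: 1.73

Compound 3 cannot be separated from the other two compounds on these numbers, as the gaps to it are a number 0.10 log units higher from compound 1 to compound 3 (within the scatter) and a number 0.03 log units higher from compound 2 to compound 3 (within the scatter). The remaining gap is a number 0.07 log units higher from compound 1 to compound 2 (within the scatter). Compound 4 `CCCC(=O)OC[C@H]1O[C@@H](n2cnc3c(N)ncnc32)[C@@H](O)[C@@H]1O` differs from compound 3 as follows: methyl in place of phenyl on a saturated chain carbon, two bonds along the chain from a carbonyl carbon. In words, this is methyl in place of phenyl on a saturated chain carbon, two bonds along the chain from a carbonyl carbon, or phenethyl to propyl. The closest evidence is the phenethyl swap in a number 0.10 log units higher from compound 1 to compound 3 (within the scatter), which stayed small. Among the compounds with values here, no measured compound carries propyl, so that evidence is indirect, and only a modest fall is expected in this assay. The expected step is a number 0.28 log units lower from compound 3 to compound 4 (within the scatter). Compound 4 is estimated at 1.45, with an expected range of 1.15 to 1.75.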

Compound 4, partition coefficient: 0.9
Estimate against measurement, compound 4: 0.55 log units above; measured number outside the range, below it.
By their numbers in this assay, from the lowest: compound 4; then compounds 1, 2 and 3 (each within the scatter of the next).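

In this assay, within the data shown here, the group on the carbonyl carbon had so far made no readable difference, but methyl in place of phenyl on a saturated chain carbon, two bonds along the chain from a carbonyl carbon, gives a number 0.83 log units lower from compound 3 to compound 4 (beyond the scatter). Propyl also stands apart from neopentyl, with a number 0.80 log units lower from compound 2 to compound 4 (beyond the scatter), and from tert-butyl, with a number 0.73 log units lower from compound 1 to compound 4 (beyond the scatter), while those three larger groups remain within the scatter of each other. Nothing available accounts for this step.

The compounds shown leave open whether a longer chain, such as hexyl, would bring the number back towards that of compound 3. From the compounds shown here alone, how an amine or a carboxylic acid at the end of the chain would read also remains open.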